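This account rests on a few compounds, and the source may have more. Where it says the series, first, only, none or still open, it means among the compounds named here.

Working notes on the urea series in an assay on isolated protein for activation of Nicotinamide phosphoribosyltransferase (Homo sapiens); a lower number here means that less compound is needed, a higher number that more compound is needed for the effect.

Compound 1 `CNS(=O)(=O)c1ccc(NC(=O)NCc2ccncc2)cc1` gives 3230 nM in this assay. Compound 2 `CCOC(=O)c1ccc(NC(=O)NCc2cc[nH]n2)cc1` gives 69000 nM in this assay. Among the measured compounds shown here, compound 3 `CN(C1CCCC1)S(=O)(=O)c1ccc(NC(=O)NCc2ccncc2)cc1` gives 123 nM in this assay, the lowest of the three numbers so far; the nearest is compound 1, and compound 2 stands far higher still. For the measured compounds named here, the one single-point step measured is a 26-fold lower number from compound 1 to compound 3 (1.42 log units; beyond the scatter), so filling the sulfonamide nitrogen with a five-membered ring of carbon brought a large drop in the number needed.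

Compound 4 `O=C(NCc1ccncc1)Nc1ccc(S(=O)(=O)c2ccc(Cl)cc2)cc1` is the next candidate. It differs from compound 3 by 4-chlorophenyl in place of cyclopentyl(methyl)amino on a sulfonyl sulfur. Going by the values given here, only the step from compound 1 to compound 3 bears on this: it shows that the sulfonyl end tolerates, and rewards, a bulky substituent, but it says nothing about removing the nitrogen and placing a six-membered aromatic ring with a chlorine directly on the sulfonyl sulfur. Compound 4 keeps a group of the same heavy-atom count at that position, so the expectation is a modest move, most likely toward a somewhat higher number, with the exact size uncertain.

Compound 4 is expected to give 300 nM in this assay, within 60 nM to 1500 nM. Compound 4 is thus expected to show a 2.4-fold higher number from compound 3 to compound 4 (0.39 log units; beyond the scatter).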

Compound 4, half-maximal effective concentration: 126 nM
The estimate for compound 4 lay 2.4-fold (0.38 log units) above the measured number, and the stated range covers the measured number.
By their numbers in this assay, from the lowest: compounds 3 and 4 (each within the scatter of the next); then compound 1; then compound 2.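

In this assay the swap gives a 1.0-fold higher number from compound 3 to compound 4 (0.01 log units; within the scatter), so at this position on a sulfonyl sulfur 4-chlorophenyl and cyclopentyl(methyl)amino cannot be told apart, although one is a six-membered aromatic ring and the other a five-membered non-aromatic ring with a nitrogen on the sulfur. A nitrogen on the sulfonyl sulfur is therefore not required for a number at this level, and the large gain seen earlier as a 26-fold lower number from compound 1 to compound 3 (1.42 log units; beyond the scatter) is not tied to that one group, as 4-chlorophenyl in place of methylamino gives a 26-fold lower number from compound 1 to compound 4 (1.41 log units; beyond the scatter). No measurement at hand accounts for the match between these two different groups.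

The compounds shown leave open whether the chlorine of 4-chlorophenyl contributes at all, and whether a plain phenyl or a ring carrying a carboxylic acid in place of that chlorine would hold the number at this level. Also open, on these data alone, is how a piperidine on the sulfonyl sulfur would compare with cyclopentyl(methyl)amino, and whether a carbonyl could replace the sulfonyl group with either of these two groups kept.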